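From Phenyl to 2,4-Difluorophenyl on the Shared Core

A few compounds are considered here, and "the series" means these few. Any claim that something is new, unique, unknown or untested is made for them only; others in the source may bear on it.

In a functional assay on CAPAN-1 cells (Homo sapiens) for antiproliferative activity, with a stated time of 72 h (on this read-out lower numbers stand for stronger inhibition and higher numbers for weaker inhibition), compound 1 (`Nc1ncnn2c([C@@H]3O[C@H](CO)[C@@H](O)[C@H]3O)cc(C#Cc3ccccc3)c12`) gives 37700 nM, and compound 2 (`Nc1ncnn2c([C@@H]3O[C@H](CO)[C@@H](O)[C@H]3O)cc(-c3ccccc3)c12`) gives 65200 nM. Among the compounds with values here, these two numbers lie within the scatter of each other, so compound 2 stands level with compound 1, its only measured neighbour. Compound 3 (`Nc1ncnn2c([C@@H]3O[C@H](CO)[C@@H](O)[C@H]3O)cc(-c3ccc(F)cc3F)c12`) carries 2,4-difluorophenyl in place of phenyl on an aromatic carbon. Within the data shown here, one measured step bears on this place, the exchange of 2-phenylethynyl for phenyl, a 1.7-fold higher number from compound 1 to compound 2 (0.24 log units; within the scatter). Among the measured compounds shown here, that step stayed within the scatter, but no measured compound carries fluorine on its phenyl ring, so the evidence is indirect. No step beyond the scatter is therefore expected in this assay, and no direction is clearly favoured. The estimated change is a 1.2-fold lower number from compound 2 to compound 3 (0.07 log units; within the scatter). For compound 3 the expected value is 55000 nM, with an estimated range from 22000 nM to 130000 nM.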

Compound 3, half-maximal inhibitory concentration: 50900 nM
Estimate against measurement, compound 3: 1.1-fold (0.03 log units) above; the range from low to high includes it.
By their numbers in this assay, from the lowest: compounds 1, 3 and 2 (each within the scatter of the next).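

In this assay, within the data shown here, 2,4-difluorophenyl in place of phenyl gives a 1.3-fold lower number from compound 2 to compound 3 (0.11 log units; within the scatter), so this is the first direct measurement of fluorine on the phenyl ring at this aromatic carbon, and the step stays within the scatter. Setting 2,4-difluorophenyl in place of 2-phenylethynyl gives a 1.4-fold higher number from compound 1 to compound 3 (0.13 log units; within the scatter), which also stays within the scatter, so all three groups tried at this position now stand level with one another. Nothing measured here explains this flat result.

With no step beyond the scatter at this carbon, the compounds shown leave open whether any group placed there can move the read-out at all. An amine, a carboxylic acid or a longer alkyl chain at this position could test that, and a single fluorine on the phenyl ring remains an open case as well.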